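The compounds below may be only part of what the source reports. "The series", "measured", "known", "first", "only" and "open" are said of these compounds alone.

In a functional assay on NCI-H292 cells (Homo sapiens) for antiproliferative activity (on this read-out higher numbers stand for weaker inhibition and lower numbers for stronger inhibition), the measured compounds stand as follows.
Compound 1 `O=C1N/C(=C\c2ccc(O)cc2)C(=O)N1c1ccc(I)cc1`: 25500 nM.
Compound 2 `CCOC(=O)c1ccc(N2C(=O)N/C(=C\c3ccc(O)cc3)C2=O)cc1`: a limit of the assay, > 200000 nM.
Compound 3 `O=C(NCC1CCCCC1)c1cccc(N2C(=O)N/C(=C\c3ccc(O)cc3)C2=O)c1`: 17900 nM.

Among the compounds with values here, compound 2 therefore gives no number; it is the one member sitting at the limit (the limit of > 200000 nM in this assay, at which 1 of the 3 values shown sits). Compound 4 `O=C(Nc1ccc(Cl)cc1)c1ccc(N2C(=O)N/C(=C\c3ccc(O)cc3)C2=O)cc1` differs from compound 2 by (4-chlorophenyl)amino in place of ethoxy on a carbonyl carbon. Within the data shown here, the only measured step touching compound 2 is an at least 7.8-fold higher number from compound 1 to compound 2 (0.89 log units; beyond the scatter), and it concerns a different place, the aromatic substituent rather than the ester. Compound 3, an amide, and compound 2 cannot be put on a single step as they differ in more than one place; their two values merely show an amide giving a measurable number. The amide in compound 4 is thus expected to bring the number back inside the range, an at least 6.6-fold lower number from compound 2 to compound 4 (0.82 log units; beyond the scatter). Compound 4 is estimated at 30000 nM, range 8000 nM to 150000 nM.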

Compound 4, half-maximal inhibitory concentration: > 200000 nM
Compound 4 was reported as a limit; the forecaster's own chance of this, stated with the estimate: 15%; middle value at least 6.6-fold (0.82 log units) away from the limit.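

In this assay compound 4 gives > 200000 nM, a limit of the assay and not a number. The (4-chlorophenyl)carbamoyl group in place of iodo on an aromatic carbon gives an at least 7.8-fold higher number from compound 1 to compound 4 (0.89 log units; beyond the scatter), so this anilide, like the ethyl ester, yields no measurable number at this place. The step from compound 2 to compound 4 cannot be read, as both compounds end at the same limit: the limit of > 200000 nM in this assay, at which 2 of the 4 values shown sit.

As far as these compounds go, whether a carboxylic acid or a methylamide on this carbonyl carbon would give a number remains open. From the compounds shown here alone, the true values of compound 2 and compound 4 also remain open.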